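This account rests on a few compounds, and the source may have more. Where it says the series, first, only, none or still open, it means among the compounds named here.

Compound 1 `COc1ccc(Nc2ncc3c(n2)N(C2CCCC2)CC(=O)N3C)cc1` is measured in a functional assay on MDA-MB-231 cells (Homo sapiens) for inhibition, read by MTT assay, with a stated time of 48 h; on this read-out lower numbers stand for stronger inhibition and higher numbers for weaker inhibition. In this assay compound 1 gives > 30000 nM, which is a limit of the assay rather than a number. The same is true of its two companions: compound 2 `CCN1C(=O)CN(C2CCCC2)c2nc(Nc3ccc(OC)cc3)ncc21`, carrying a methyl in place of hydrogen on a saturated chain carbon bound to an amide-type nitrogen in a ring, gives in this assay a value of > 30000 nM, again a limit. Compound 3 `O=C1CN(C2CCCC2)c2nc(Nc3ccc(N4CCNCC4)cn3)ncc2N1`, built on a different arrangement of the shared core, gives in this assay a value of > 30000 nM, also a limit. Going by the values given here, the only single-point step among them, a step that the two limits leave unreadable from compound 1 to compound 2, is therefore unreadable, and the whole picture rests on (the limit of > 30000 nM in this assay, at which 3 of the 3 values shown sit).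

Compound 4 `CN1CCN(c2ccc(Nc3ncc4c(n3)N(C3CCCC3)CC(=O)N4C)cc2)CC1` differs from compound 1 by 4-methylpiperazin-1-yl in place of methoxy on an aromatic carbon, a 4-methylpiperazin-1-yl in place of methoxy on an aromatic carbon of a six-membered aromatic ring of carbon only, para to a large group. Among the compounds with values here, no measured step bears on this change, and compound 3, which also carries a piperazine, sits at the limit. On that basis compound 4 is expected to remain weak, with an estimated step of an at least 1.2-fold lower number from compound 1 to compound 4 (0.07 log units; that floor lies within the scatter), giving an estimate of 25000 nM in this assay, ranging from 5000 nM to 60000 nM.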

Compound 4, half-maximal inhibitory concentration: 10300 nM
For compound 4 the middle estimate is 2.4-fold (0.39 log units) above the measured one, and the stated range covers the measured number.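

Setting 4-methylpiperazin-1-yl in place of methoxy on this aromatic carbon, para to a large group, gives the first step in this assay that can be read: an at least 2.9-fold lower number from compound 1 to compound 4 (0.46 log units; beyond the scatter). Going by these compounds alone, this position therefore responds to a change of group, which the earlier compounds could not show, and compound 4 is the first to give a number rather than a limit. The step from compound 1 to compound 2 still cannot be read, and the picture remains dominated by one limit: the limit of > 30000 nM in this assay, at which 3 of the 4 values shown sit.

From the compounds shown here alone, the step starts from a limit, so its full size remains open. Also open, going by these compounds, is whether a morpholin-4-yl ring, a dimethylamino group or a longer chain ending in an amine would behave like 4-methylpiperazin-1-yl at this position.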